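Dimethylaminophenyl for Hydroxyphenyl on the Pyrazoline Carbon

The compounds below may be only part of what the source reports. "The series", "measured", "known", "first", "only" and "open" are said of these compounds alone.

Compound 1 `O=C1N=C(N2N=C(c3ccccc3)CC2c2ccccc2O)S/C1=C1/C(=O)Nc2ccccc21` gives 2040 nM in a functional assay on cells (Melanoma cell, Homo sapiens) for cytotoxicity, read by sulforhodamine B assay, with a stated time of 48 h; on this read-out higher numbers stand for weaker inhibition of growth and lower numbers for stronger inhibition of growth. Going by the values given here, compound 2 `O=C1N=C(N2N=C(c3ccccc3)CC2c2ccccc2O)S/C1=C1/C(=O)Nc2ccc(Br)cc21` gives 230 nM, and the single step of an 8.9-fold lower number from compound 1 to compound 2 (0.95 log units; beyond the scatter) is the only one-place change measured here. Compound 3 `COc1ccc(C2=NN(C3=NC(=O)/C(=C4\C(=O)Nc5ccc(Cl)cc54)S3)C(c3ccc(Cl)cc3)C2)cc1` differs from compound 2 in several places at once. In this assay compound 3 gives 200 nM, and its number and that of compound 2 lie within the scatter of each other. Compound 2 therefore stands second highest of the three numbers, set apart from compound 1 but not from compound 3.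

Compound 4 `CN(C)c1ccc(C2CC(c3ccccc3)=NN2C2=NC(=O)/C(=C3\C(=O)Nc4ccc(Br)cc43)S2)cc1` is made from compound 2 by one change: 4-(dimethylamino)phenyl in place of 2-hydroxyphenyl on a saturated ring carbon. Among the compounds with values here, no measured step touches this position, and the one step available, an 8.9-fold lower number from compound 1 to compound 2 (0.95 log units; beyond the scatter), concerns a different part of the molecule. Within the data shown here, the only hint is that compound 3, whose saturated ring carbon carries a different aryl group among other changes, sits close to compound 2. The expected step in this assay is therefore none beyond the scatter, a 1.1-fold higher number from compound 2 to compound 4 (0.04 log units; within the scatter), and compound 4 is estimated at 250 nM, within 80 nM to 800 nM.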

Compound 4, concentration for 50% growth inhibition: 200 nM
Estimate against measurement, compound 4: 1.3-fold (0.10 log units) above, and the stated range covers the measured number.
By their numbers in this assay, from the lowest: compounds 3, 4 and 2 (each within the scatter of the next); then compound 1.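

In this assay, going by these compounds alone, the exchange gives a 1.2-fold lower number from compound 2 to compound 4 (0.06 log units; within the scatter), so the saturated ring carbon, which no earlier step touched, tolerates this change of aryl group with no shift beyond the scatter. The entering 4-(dimethylamino)phenyl has more heavy atoms than 2-hydroxyphenyl and no hydrogen-bond donor, so with the bromo core in place this donor is not needed for a number of this size. Nothing available here accounts for why the number holds across this exchange.

The compounds shown do not separate the change of substituent from its change of place on the phenyl ring, which a 4-hydroxyphenyl or 2-(dimethylamino)phenyl group would address. On these data alone, it also remains open whether a carboxylic acid or a morpholine on that phenyl ring would be tolerated, and whether the exchange would read the same on the core without bromo.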